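Aziridinylbenzoquinone series: replacing acetyl by 1-methoxypropyl

The source may report more compounds than this note shows. Statements on the series, on what has been measured and on what is new or still open speak of the compounds shown alone.

Measured compounds:
compound 1, `CC1=C(N2CC2)C(=O)C(C(C)C)=C(N2CC2)C1=O`: 4.96
compound 2, `CC(=O)C1=C(N2CC2)C(=O)C(C)=C(N2CC2)C1=O`: 3.94

Read-out is a functional assay on L1210 cells (Mus musculus), with a stated time of 1 days; on this read-out higher numbers stand for higher potency (the scale is a negative logarithm) and lower numbers for lower potency. Compound 2 holds the lower of the two numbers; compound 1 stands higher by a step that is beyond the scatter, namely a number 1.02 log units lower from compound 1 to compound 2 (beyond the scatter).

Compound 3, `CCC(OC)C1=C(N2CC2)C(=O)C(C)=C(N2CC2)C1=O`, is not yet measured. It differs from compound 2 in one place: 1-methoxypropyl in place of acetyl on a double-bonded ring carbon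

Going by the values given here, only one measured step bears on this change. The acetyl that enters from compound 1 to compound 2 is the same acetyl that leaves from compound 2 to compound 3, and that step was large, a number 1.02 log units lower from compound 1 to compound 2 (beyond the scatter). Among the compounds with values here, no measured pair shows a 1-methoxypropyl, so its own contribution is unknown; the 1-methoxypropyl of compound 3 is, like the isopropyl of compound 1, a saturated branched group without a double bond, which is all the structures show. A step upward is therefore expected for compound 3, though smaller than the full reversal because a number 1.02 log units lower from compound 1 to compound 2 (beyond the scatter) was measured with the isopropyl of compound 1 and the group entering compound 3 is not that isopropyl. For compound 3 the expected step is roughly a number 0.66 log units higher from compound 2 to compound 3 (beyond the scatter). Compound 3 is estimated at 4.6 in this assay, within 3.9 to 5.3.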

Compound 3, logarithm of the reciprocal of the active concentration, log(1/C): 5.26
Compound 3: middle estimate off by 0.66 log units, on the low side; the measured number falls inside the stated range.
By their numbers in this assay, from the lowest: compound 2; then compounds 1 and 3 (each within the scatter of the next).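

In this assay, the position that carries acetyl in compound 2 is not limited to the low number seen there: 1-methoxypropyl gives a number 1.32 log units higher from compound 2 to compound 3 (beyond the scatter), and against isopropyl it gives a number 0.30 log units higher from compound 1 to compound 3 (within the scatter), so these two saturated groups cannot be told apart on this read-out. Acetyl and 1-methoxypropyl each count one hydrogen-bond acceptor, so that count does not separate compound 2 from compound 3, whereas the double bond outside the ring is present only in the acetyl group. Nothing measured here accounts for either step, and the size of the acetyl step remains an observation without a stated cause.

Whether the oxygen of 1-methoxypropyl contributes anything remains open: a plain butyl chain or a 1-hydroxypropyl group on this double-bonded ring carbon is absent from the compounds shown. On these data alone, all three compounds also keep the methyl group or the acetyl and isopropyl groups within a narrow set, so it is unknown whether these steps would carry over with an ethyl group on the ring atom that bears the methyl group.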